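The source may report more compounds than this note shows. Statements on the series, on what has been measured and on what is new or still open speak of the compounds shown alone.

Compound 3 `Cc1nn(-c2ncnc3nc[nH]c23)c2c1C(OCc1ccc(C#N)cc1)CC(=O)N2` gives 4 nM in a functional assay on HEK293 cells for agonist activity at G-protein coupled receptor 39 (Homo sapiens), read by scintillation proximity assay and inositol phosphate accumulation, with a stated time of 75 min, in the presence of a further agent that is not named here (a higher number here means that more compound is needed for the effect, a lower number that less compound is needed), and stands level with compound 1 `Cc1nn(-c2ncnc3nc[nH]c23)c2c1C(OCc1ccccc1F)CC(=O)N2` at 4 nM; together they are the lowest of the three numbers, and compound 2 `Cc1cc(C)n(CCOC2CC(=O)Nc3c2c(C)nn3-c2ncnc3nc[nH]c23)n1` at 16 nM is the furthest from them. The measured steps all lie at the same position, the group on the saturated chain carbon bound to the oxygen: no change at the digits printed from compound 1 to compound 3 (within the scatter), a 4.0-fold higher number from compound 1 to compound 2 (0.60 log units; beyond the scatter) and a 4.0-fold lower number from compound 2 to compound 3 (0.60 log units; beyond the scatter). Compound 4 `Cc1nn(-c2ncnc3nc[nH]c23)c2c1C(NC(=O)Cc1cccs1)CC(=O)N2` differs from compound 3 by (((thiophen-2-yl)methyl)carbonyl)amino in place of (4-cyanobenzyl)oxy on a saturated ring carbon. For the measured compounds named here, this change is larger than any of the measured steps, as the oxygen link itself is replaced by an amide, so none of the three steps bears on it directly; they show only that the position tolerates exchange of the aryl group within a modest range. Compound 4 is therefore expected to show a modest loss, a 3.8-fold higher number from compound 3 to compound 4 (0.57 log units; beyond the scatter), with wide uncertainty. The estimate for compound 4 in this assay is 15 nM, within a range from 4 nM to 60 nM.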

Compound 4, half-maximal effective concentration: 3 nM
Estimate against measurement, compound 4: 5.0-fold (0.70 log units) above; measured number outside the range, below it.
By their numbers in this assay, from the lowest: compounds 4, 1 and 3 (each within the scatter of the next); then compound 2.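

In this assay the ether link on the saturated ring carbon is not needed to hold the number: (((thiophen-2-yl)methyl)carbonyl)amino gives a 1.3-fold lower number from compound 3 to compound 4 (0.12 log units; within the scatter) against (4-cyanobenzyl)oxy and a 1.3-fold lower number from compound 1 to compound 4 (0.12 log units; within the scatter) against (2-fluorobenzyl)oxy. The position therefore accepts a change of link and of aromatic ring together, and the amide also stands clear of the pyrazole-bearing ether, with a 5.3-fold lower number from compound 2 to compound 4 (0.73 log units; beyond the scatter) as the step. No measurement on hand accounts for this tolerance.

As far as these compounds go, the link and the aromatic ring change together from compound 3 to compound 4, so the share of each stays open. Also open, from the compounds shown here alone, is how the number responds at this carbon to a plain amine, a carboxylic acid, or a longer chain in the amide group.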